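A Quinolinyl Sulfonamide Awaits Its Cytotoxicity Reading

The source may report more compounds than this note shows. Statements on the series, on what has been measured and on what is new or still open speak of the compounds shown alone.

Three sulfonamides sharing one core have been examined in an ADME assay on HepG2 2.2.15 cells (Homo sapiens) for cytotoxicity; a higher number here means that more compound is tolerated, a lower number that less compound is tolerated. Compound 1 (`Cc1ccc(C)c(S(=O)(=O)Nc2ncc(C(Oc3ccc4cc(Br)ccc4c3)c3ccc(Cl)cc3)s2)c1`) gives in this assay > 50000 nM, which is a limit of the assay and not a number. Compound 2 (`O=S(=O)(Nc1ncc(C(Oc2ccc3cc(Br)ccc3c2)c2ccc(Cl)cc2)s1)c1ccc(Cl)cc1`) is reported in this assay as "not toxic" (no number reported), without a number. Compound 3 (`O=S(=O)(Nc1ncc(C(Oc2ccc3cc(Br)ccc3c2)c2ccc(Cl)cc2)s1)c1ccc2c(c1)CCO2`) gives in this assay > 50000 nM, again a limit rather than a number. Among the measured compounds shown here, the only step between compounds differing in one place is a step that the two limits leave unreadable from compound 1 to compound 3, whose size cannot be read because both ends sit at the limit of > 50000 nM in this assay, at which 2 of the 3 values shown sit. Compound 3 thus stands at the limit, as compound 1 does, with compound 2 described only in words.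

Compound 4 (`O=S(=O)(Nc1ncc(C(Oc2ccc3cc(Br)ccc3c2)c2ccc(Cl)cc2)s1)c1cccc2cccnc12`) differs from compound 3 by a group of 10 heavy atoms (9 carbon, 1 nitrogen; one six-membered aromatic ring of carbon only, one six-membered aromatic ring with 1 hetero atom) in place of a group of 9 heavy atoms (8 carbon, 1 oxygen; one five-membered non-aromatic ring with 1 hetero atom, one six-membered aromatic ring of carbon only), on a sulfonyl sulfur. For the measured compounds named here, no measured step with a readable size bears on this change; the one step available was unreadable. No step beyond the scatter is therefore expected in this assay, and compound 4 is expected to remain at the limit. The expected step for compound 4 is a step that the limit leaves unreadable from compound 3 to compound 4. For compound 4 the estimate in this assay is 60000 nM, with a range from 30000 nM to 120000 nM.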

Compound 4, half-maximal cytotoxic concentration: > 50000 nM
Compound 4 was reported as a limit (the forecaster's own chance of this, stated with the estimate: 75%); the middle value is on the limit's open side.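

In this assay compound 4 gives > 50000 nM, which is a limit and not a number. The steps to compound 4 from compound 1 and from compound 3 therefore cannot be read: the limit of > 50000 nM in this assay, at which 3 of the 4 values shown sit.

The compounds shown leave open whether any group on the sulfonyl sulfur changes how much compound is tolerated.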